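This account rests on a few compounds, and the source may have more. Where it says the series, first, only, none or still open, it means among the compounds named here.

Compound 3, `COc1cc(C(=O)/C=C\Nc2ccc(-c3nc4cc(OC)c(OC)c(OC)c4s3)cc2C)cc(OC)c1OC`, gives 12900 nM in a functional assay on MDA-MB-231 cells (Homo sapiens) for antiproliferative activity, read by sulforhodamine B assay, with a stated time of 48 h; a higher number here means a weaker inhibitor, a lower number a stronger inhibitor. Compound 1, `COc1cc(OC)c2sc(-c3ccc(N/C=C\C(=O)c4cc(OC)c(OC)c(OC)c4)c(C)c3)nc2c1`, differs from compound 3 by hydrogen in place of methoxy on an aromatic carbon, and that change brings a 1.1-fold higher number from compound 3 to compound 1 (0.03 log units; within the scatter); in this assay compound 1 gives 13800 nM. Compound 2, `COc1cc(C(=O)/C=C\Nc2ccc(-c3nc4cc(OC)c(OC)c(OC)c4s3)cc2)cc([N+](=O)[O-])c1OC`, gives 9800 nM in this assay; how its core and that of compound 3 differ is not broken down here, and compound 3 at 12900 nM sits within the scatter of that number. Compound 4, `COc1cc(OC)c2sc(-c3ccc(N/C=C\C(=O)c4cc(OC)c(OC)c([N+](=O)[O-])c4)cc3)nc2c1`, is not yet measured in this assay. It differs from compound 2 by hydrogen in place of methoxy on an aromatic carbon, the same change as from compound 3 to compound 1, at a place described in the same words. The step expected from compound 2 to compound 4 is a 1.1-fold higher number from compound 2 to compound 4 (0.05 log units; within the scatter), resting on the earlier step of a 1.1-fold higher number from compound 3 to compound 1 (0.03 log units; within the scatter). Compound 4 is therefore expected to give 11000 nM, with a range from 5000 nM to 25000 nM, taken from compound 2 at 9800 nM.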

Compound 4, half-maximal inhibitory concentration: 3060 nM
The estimate for compound 4 lay 3.6-fold (0.56 log units) above the measured number, outside the stated range (below it).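

In this assay, hydrogen in place of methoxy on an aromatic carbon brings a 3.2-fold lower number from compound 2 to compound 4 (0.51 log units; beyond the scatter), and the size of this step does not carry over from one core to the other: the same change on two cores in this assay, a 1.1-fold higher number (0.03 log units; within the scatter) from compound 3 to compound 1 and a 3.2-fold lower number (0.51 log units; beyond the scatter) from compound 2 to compound 4, 3.4-fold (0.53 log units) apart, beyond the scatter of two such steps A step measured for this change on one core is therefore a poor guide to its size on the other. This rests on two pairs only, and it shows neither which difference between the cores goes with the gap nor why the gap arises.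

Still open, from the compounds shown here alone, is whether the same change on further cores would follow compound 3 and compound 1 or compound 2 and compound 4. Also open, going by these compounds, is how an amine or a carboxylic acid at that aromatic carbon would read in this assay.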